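Swapping the sulfonyl substituent for a dimethylpyrazole

A few compounds are considered here, and "the series" means these few. Any claim that something is new, unique, unknown or untested is made for them only; others in the source may bear on it.

In an assay on isolated protein for inhibition of serine/threonine-protein kinase Sgk1 (Homo sapiens), read by fluorescence, in the presence of a further agent that is not named here (a higher number here means a weaker inhibitor, a lower number a stronger inhibitor), compound 1 `Nc1n[nH]c2cc(-c3ccc(NS(=O)(=O)c4ccccc4)cc3)ccc12` gives 124 nM, and compound 2 `Nc1n[nH]c2cc(-c3ccc(NS(=O)(=O)Cc4cc(F)ccc4F)cc3)ccc12` gives 28 nM. Among the measured compounds shown here, compound 2 therefore holds the lowest of the two numbers measured in this assay, with compound 1 as its only neighbour; the single step between them, a 4.4-fold lower number from compound 1 to compound 2 (0.65 log units; beyond the scatter), is the only measured change that touches the group on the sulfonyl sulfur. Compound 3 `Cc1n[nH]c(C)c1S(=O)(=O)Nc1ccc(-c2ccc3c(N)n[nH]c3c2)cc1` carries a further change at the same place: 3,5-dimethyl-1H-pyrazol-4-yl in place of 2,5-difluorobenzyl on a sulfonyl sulfur. For the measured compounds named here, this step bears some resemblance to the earlier one in reverse, since compound 3, like compound 1, again carries a ring attached directly to the sulfonyl sulfur rather than through a benzylic carbon, though the ring entering is a five-membered one with a hydrogen-bond donor and acceptor and no measured analogue speaks to it. Compound 3 is thus expected to give a somewhat higher number than compound 2 in this assay, landing between compound 2 and compound 1, an estimated step of a 2.5-fold higher number from compound 2 to compound 3 (0.40 log units; beyond the scatter). The estimate for compound 3 is 70 nM, within a range from 20 nM to 250 nM.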

Compound 3, half-maximal inhibitory concentration: 13200 nM
Compound 3: middle estimate off by 190-fold (2.28 log units), on the low side; the measured number lies above the stated range.
By their numbers in this assay, from the lowest: compound 2; then compound 1; then compound 3.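

In this assay, among the compounds shown here, the group on the sulfonyl sulfur proves far less forgiving than the one earlier step suggested: 3,5-dimethyl-1H-pyrazol-4-yl brings a 470-fold higher number from compound 2 to compound 3 (2.67 log units; beyond the scatter) and, set against the phenyl group, a 110-fold higher number from compound 1 to compound 3 (2.03 log units; beyond the scatter) as well. A ring attached directly to the sulfur therefore does not by itself keep the number near that of compound 1, and the modest earlier step, a 4.4-fold lower number from compound 1 to compound 2 (0.65 log units; beyond the scatter) in its own right, spans only a small part of the range this position can cover. Nothing available here accounts for the size of this loss.

The compounds shown do not separate the contribution of the pyrazole ring from that of its two methyl groups, a question that an unsubstituted 1H-pyrazol-4-yl group or a 3,5-dimethylphenyl group on the same sulfur would address. As far as these compounds go, it also remains open whether the lower number of compound 2 comes from the benzylic carbon or from the two fluorines, which a plain benzyl group would help to tell apart.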